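The source may hold more compounds than are shown below. What is called first, only, known or untested is meant among the compounds shown, and "the series" means these compounds.

Three compounds in this set share one core and differ in the group on the sulfonyl and in the substituent on the side-chain nitrogen. In an assay on isolated protein for displacement of a labelled ligand from 5-hydroxytryptamine receptor 6 (Homo sapiens) (on this read-out higher numbers stand for weaker inhibition and lower numbers for stronger inhibition), compound 1 `CNCC1CCCc2cc(S(=O)(=O)c3ccccc3)ccc21` gives 0.316 nM, and compound 2 `NC[C@@H]1CCCc2cc(S(=O)(=O)c3cc[nH]c3)ccc21` gives 0.316 nM. Compound 3 `O=C(NC[C@@H]1CCCc2cc(S(=O)(=O)c3cccc(F)c3)ccc21)c1ccc[nH]1` stands at the top of these three numbers, with 5.01 nM in this assay, a higher number than either of the other two by more than the usual scatter. Compound 4 `CC(C)(O)C(=O)NC[C@@H]1CCCc2cc(S(=O)(=O)c3cccc(F)c3)ccc21` differs from compound 3 in one place: 1-hydroxy-1-methylethyl in place of 1H-pyrrol-2-yl on a carbonyl carbon. For the measured compounds named here, no measured pair shows this kind of change, so only a modest shift is expected. The estimated step of a 1.6-fold higher number from compound 3 to compound 4 (0.20 log units; within the scatter) is expected to be small, toward a somewhat higher number. Compound 4 is expected at 8 nM, within an estimated range from 2 nM to 40 nM.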

Compound 4, inhibition constant: 2 nM
For compound 4 the middle estimate is 4.0-fold (0.60 log units) above the measured one; the range from low to high includes it.
By their numbers in this assay, from the lowest: compounds 1 and 2 (each within the scatter of the next); then compound 4; then compound 3.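

In this assay, for the compounds shown here, the change gives a 2.5-fold lower number from compound 3 to compound 4 (0.40 log units; beyond the scatter) and is the first one-place comparison in this set. It shows that this carbonyl carbon does not need the 1H-pyrrol-2-yl ring to keep a low number, since 1-hydroxy-1-methylethyl, which has no ring, gives a lower one. Nothing given here accounts for the shift. Still open, on these data alone, is how an amine, a carboxylic acid or a longer chain would fare on this carbonyl carbon. As far as these compounds go, it is also open whether the step would hold with another group on the sulfonyl.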